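This account rests on a few compounds, and the source may have more. Where it says the series, first, only, none or still open, it means among the compounds named here.

In an assay on cells with melanin-concentrating hormone receptor 1 (Homo sapiens) as the target, read by radioligand binding (on this read-out higher numbers stand for weaker inhibition and lower numbers for stronger inhibition), compound 2, `Nc1ccc2cccc(OCCC3CCCCC3)c2n1`, gives 808 nM, the highest of the three numbers recorded. Compound 1, `CC1CCCCC1Oc1cccc2ccc(N)nc12`, gives 32 nM in this assay, and compound 3, `Nc1ccc2cccc(OCC3CC4CCC3C4)c2n1`, gives 137 nM; both lie beyond the scatter from compound 2, so compound 2 is the weakest of the three measured. Compound 4, `CC(C)(C)CCOc1cccc2ccc(N)nc12`, has not been measured. It differs from compound 2 in one place: tert-butyl in place of cyclohexyl on a saturated chain carbon, two bonds along the chain from an oxygen on an aromatic ring. For the measured compounds named here, no measured pair shows this exchange, so its effect is unknown. Compound 4 is expected to remain close to compound 2, with a step of a 1.1-fold higher number from compound 2 to compound 4 (0.05 log units; within the scatter) within the scatter. The estimate for compound 4 in this assay is 900 nM, with a range from 300 nM to 3000 nM.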

Compound 4, half-maximal inhibitory concentration: 201 nM
Estimate against measurement, compound 4: 4.5-fold (0.65 log units) above, and the stated range ends above it.
By their numbers in this assay, from the lowest: compound 1; then compounds 3 and 4 (each within the scatter of the next); then compound 2.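

In this assay, for the compounds shown here, tert-butyl in place of cyclohexyl on a saturated chain carbon, two bonds along the chain from an oxygen on an aromatic ring, gives a 4.0-fold lower number from compound 2 to compound 4 (0.60 log units; beyond the scatter) and so provides the first step that can be read at this position. A ring is therefore not required at this place, since the open tert-butyl group, with fewer heavy atoms, gives the lower number. No available evidence accounts for the size of this step. Going by these compounds, whether isopropyl, a longer chain or an amine at this place would lower the number further remains open.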